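Ethoxycarbonyl to hydroxymethyl on the core of compound 1

A few compounds are considered here, and "the series" means these few. Any claim that something is new, unique, unknown or untested is made for them only; others in the source may bear on it.

compound 1 `CCOC(=O)[C@]1(C(=O)Nc2ccccc2)C[C@H]1c1cc(OC)c(OC)c(OC)c1`: > 100000 nM
compound 2 `CCOC(=O)[C@]1(C(=O)NCc2ccc(C)cc2)C[C@H]1c1cc(OC)c(OC)c(OC)c1`: 28500 nM
compound 3 `CCOC(=O)[C@]1(C(=O)Nc2ccccc2)C[C@@H]1c1cc(OC)c(OC)c(OC)c1`: > 100000 nM

In a functional assay on HeLa cells (Homo sapiens) for cytotoxicity, read by MTT assay, with a stated time of 48 h (a higher number here means a weaker inhibitor, a lower number a stronger inhibitor), compound 1 gives > 100000 nM, which is a limit of the assay and not a number. Compound 3 also gives only a limit, > 100000 nM. Compound 2 gives 28500 nM. The step of an at least 3.5-fold lower number from compound 1 to compound 2 (0.54 log units; beyond the scatter) concerns the amide-type nitrogen substituent only. The step that the two limits leave unreadable from compound 1 to compound 3 cannot be read because the limit of > 100000 nM in this assay, at which 2 of the 3 values shown sit, covers both compounds.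

Compound 4 `COc1cc([C@@H]2C[C@]2(CO)C(=O)Nc2ccccc2)cc(OC)c1OC` is compound 1 with hydroxymethyl in place of ethoxycarbonyl on a saturated ring carbon. Going by the values given here, neither measured step touches the ethoxycarbonyl, so no step bears on this change, and compound 1 sits at a limit. The step of an at least 1.1-fold lower number from compound 1 to compound 4 (0.04 log units; that floor lies within the scatter) is therefore expected to be none beyond the scatter, with wide uncertainty. Compound 4 is estimated at 90000 nM, in the range 15000 nM to 400000 nM.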

Compound 4, half-maximal inhibitory concentration: 32000 nM
Beside the measured number, compound 4's estimate is 2.8-fold (0.45 log units) above it; the range from low to high includes it.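

In this assay, the saturated ring carbon bearing ethoxycarbonyl responds to change: hydroxymethyl in place of ethoxycarbonyl gives an at least 3.1-fold lower number from compound 1 to compound 4 (0.49 log units; beyond the scatter). The earlier steps had shown a readable change only at the amide-type nitrogen, so this is a second place on the core of compound 1 where a change reads beyond the scatter. The full size of this step stays unknown, because it starts from a limit: the limit of > 100000 nM in this assay, at which 2 of the 4 values shown sit.

Open, as far as these compounds go, is whether a carboxylic acid or an aminomethyl group at this carbon goes the same way as hydroxymethyl. Also open, from the compounds shown here alone, is whether hydroxymethyl adds to the 4-methylbenzyl group of compound 2, and the step from compound 1 to compound 3 cannot be read.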